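Enantiomer of a glutarimide-type carbamate in a whole-animal assay

A few compounds are considered here, and "the series" means these few. Any claim that something is new, unique, unknown or untested is made for them only; others in the source may bear on it.

Measured compounds:
compound 1 `O=C1CC[C@H](NC(=O)OCc2ccccc2)C(=O)N1` — 42.5 mg/kg
compound 2 `O=C1C[C@@H](NC(=O)OCc2ccccc2)C(=O)N1` — 110 mg/kg
compound 3 `CN1C(=O)C[C@@H](NC(=O)OCc2ccccc2)C1=O` — 82.5 mg/kg

Of the compounds shown here, three have been measured in a functional assay on the whole organism with Mus musculus as the target; on this read-out lower numbers stand for an effect already at smaller amounts and higher numbers for an effect only at larger amounts of compound. Compound 1 gives 42.5 mg/kg, compound 2 gives 110 mg/kg and compound 3 gives 82.5 mg/kg. Compound 2 stands at the highest number of the three; its nearest neighbour is compound 3, with a 1.3-fold lower number from compound 2 to compound 3 (0.12 log units; within the scatter), and the gap to compound 1 lies beyond the scatter.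

The unmeasured compound 4 `O=C1C[C@H](NC(=O)OCc2ccccc2)C(=O)N1` differs from compound 2 as follows: the two compounds have the same atoms and bonds and differ only in configuration as drawn: 1 of 1 stereo elements differ; a stereocentre at a saturated ring carbon is drawn R in compound 2 and S in compound 4.

Going by the values given here, none of the measured steps concerns a change of configuration; the one step recorded, a 1.3-fold lower number from compound 2 to compound 3 (0.12 log units; within the scatter), alters a methyl on a ring nitrogen and lies within the scatter, so it gives no direction for the present change. Among the compounds with values here, since the data provide no step of this kind, the expectation for compound 4 in this assay is kept close to compound 2, with a wide range to allow for either direction. Compound 4 is estimated at 100 mg/kg, within 40 mg/kg to 250 mg/kg, which is expected to mean a 1.1-fold lower number from compound 2 to compound 4 (0.04 log units; within the scatter).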

Compound 4, dose for half-maximal effect: 78.1 mg/kg
Estimate against measurement, compound 4: 1.3-fold (0.11 log units) above; low and high end bracket the measured number.
By their numbers in this assay, from the lowest: compounds 1, 4, 3 and 2 (each within the scatter of the next, the first and the last beyond it).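

In this assay, turning the stereocentre at the saturated ring carbon from R to S gives a 1.4-fold lower number from compound 2 to compound 4 (0.15 log units; within the scatter), so no effect of configuration at this position can be told apart from the scatter. The earlier compounds shown here included no pair that could test this, whereas here the comparison isolates the stereocentre from every other structural feature: the fact that compounds 2 and 4 differ only in the configuration as drawn. This finding rests on a single pair and applies only to the core of compound 2 with its benzyl carbamate.

The compounds shown leave open whether configuration would matter equally little in the core of compound 1 or with the ring nitrogen methylated as in compound 3. They also leave open whether the same would hold with a free amine in place of the benzyl carbamate.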